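Replacing Methoxy with Fluoro on Compound 3

The compounds below may be only part of what the source reports. "The series", "measured", "known", "first", "only" and "open" are said of these compounds alone.

In a functional assay on HeLa cells (Homo sapiens) for inhibition, read by MTT assay, with a stated time of 72 h (a higher number here means a weaker inhibitor, a lower number a stronger inhibitor), compound 1 (`COc1ccc(-c2nnc(SCCCN3CCN(c4nc5ccccc5o4)CC3)o2)cc1`) gives 210000 nM, compound 2 (`Cc1ccc(-c2nnc(SCCCN3CCN(c4nc5ccccc5o4)CC3)o2)cc1`) gives 133000 nM and compound 3 (`COc1ccc(-c2nnc(SCCCN3CCN(c4nc5ccccc5s4)CC3)o2)cc1`) gives 165000 nM. Compound 3 thus lies within the usual scatter of both others. Compound 4 (`Fc1ccc(-c2nnc(SCCCN3CCN(c4nc5ccccc5s4)CC3)o2)cc1`) differs from compound 3 in one place, with fluoro in place of methoxy on an aromatic carbon. The nearest measured change, methyl in place of methoxy, gave a 1.6-fold lower number from compound 1 to compound 2 (0.20 log units; within the scatter). Changing the group on the ring nitrogen gave a 1.3-fold lower number from compound 1 to compound 3 (0.10 log units; within the scatter). Among the compounds with values here, both steps stay within the scatter, and no measured compound carries fluoro. The expected change is therefore small, an estimated 1.1-fold lower number from compound 3 to compound 4 (0.04 log units; within the scatter), with none beyond the scatter. Compound 4 is estimated at 150000 nM, with an expected range from 80000 nM to 280000 nM.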

Compound 4, half-maximal inhibitory concentration: 134000 nM
For compound 4 the middle estimate is 1.1-fold (0.05 log units) above the measured one, and the stated range covers the measured number.
By their numbers in this assay, from the lowest: compounds 2, 4, 3 and 1 (each within the scatter of the next).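

In this assay, fluoro replaces methoxy on the six-membered aromatic ring with a 1.2-fold lower number from compound 3 to compound 4 (0.09 log units; within the scatter), so this assay does not separate the two groups at this position. Within the data shown here, this is also the first step here to remove the hydrogen-bond acceptor counted on methoxy, and the number still stays within the scatter. Nothing measured here explains this result. Going by these compounds, it remains open whether a larger change at this position, such as an amine or a carboxylic acid, would move the number beyond the scatter. On these data alone, it is also open whether fluoro would behave the same way alongside 1,3-benzoxazol-2-yl.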